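The compounds below may be only part of what the source reports. "The series", "measured", "known", "first", "only" and "open" are said of these compounds alone.

Working notes on the series.

For the measured compounds named here, compound 3 `C#Cc1cn([C@@H]2O[C@H](CO)[C@@H](O)[C@H]2O)c2ncnc(C)c12` is the one member with a number in a functional assay on A549 cells (Homo sapiens), read by MTT assay, with a stated time of 72 h; on this read-out higher numbers stand for weaker inhibition and lower numbers for stronger inhibition: compound 3 gives 19200 nM. The other two members give only limits there. Compound 1 `Cc1ncnc2c1c(-c1ccoc1)cn2[C@@H]1O[C@H](CO)[C@@H](O)[C@H]1O` returns a limit in this assay, > 20000 nM. Compound 2 `CSc1ncnc2c1c(-c1cccs1)cn2[C@@H]1O[C@H](CO)[C@@H](O)[C@H]1O` likewise returns a limit in this assay, > 20000 nM. Going by the values given here, the one measured step, ethynyl in place of furan-3-yl on an aromatic carbon, amounts to an at least 1.0-fold lower number from compound 1 to compound 3 (0.01 log units; that floor lies within the scatter), and as it starts from a limit it can be read only as a floor; the weight of the data sits at the limit of > 20000 nM in this assay, at which 2 of the 3 values shown sit.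

Compound 4 `C#Cc1cn([C@@H]2O[C@H](CO)[C@@H](O)[C@H]2O)c2ncnc(SC)c12` is not yet measured. It differs from compound 3 in one place: methylsulfanyl in place of methyl on an aromatic carbon. Among the compounds with values here, no measured step touches this change, since the pair compound 1 and compound 2 differ in two places and both sit at the limit, so their values show nothing about methylsulfanyl against methyl on its own. With compound 3 close to the limit already, the expectation is for compound 4 to stay near it, with the expected step of a 1.1-fold higher number from compound 3 to compound 4 (0.06 log units; within the scatter) anticipated to lie within the scatter. The estimate for compound 4 in this assay is 22000 nM, in the range 8000 nM to 60000 nM.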

Compound 4, half-maximal inhibitory concentration: 140 nM
Estimate against measurement, compound 4: 160-fold (2.20 log units) above; measured number below the stated range.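

For the compounds shown here, with ethynyl held constant, methylsulfanyl in place of methyl on the aromatic carbon next to the ring nitrogen gives a 140-fold lower number from compound 3 to compound 4 (2.14 log units; beyond the scatter) in this assay, so this position, which the earlier compounds left unresolved, can carry a large change in the read-out. Methylsulfanyl alone does not secure that change: compound 2 carries the same group with thiophen-2-yl instead of ethynyl, and the exchange of those two groups gives an at least 140-fold lower number from compound 2 to compound 4 (2.15 log units; beyond the scatter), a step that starts from a limit and so reads only as a floor. Among the compounds shown, only the one combining ethynyl with methylsulfanyl stands clear of the top of the measured range, whereas the earlier values lay close to or at the limit: the limit of > 20000 nM in this assay, at which 2 of the 4 values shown sit.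

The compounds shown leave open whether the effect at this carbon is specific to methylsulfanyl or would also appear with an amine, a methoxy group or a longer thioether chain. They also leave open whether a nitrile or a short alkyl chain could stand in for ethynyl while methylsulfanyl is kept.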